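This account rests on a few compounds, and the source may have more. Where it says the series, first, only, none or still open, it means among the compounds named here.

Of the compounds shown here, three sharing one core have been measured in a functional assay on LNCaP cells (Homo sapiens) for antiproliferative activity; on this read-out lower numbers stand for stronger inhibition and higher numbers for weaker inhibition. Compound 1 (`Cn1ncc(Cl)c1-c1cc(C(=O)N[C@@H]2CN[C@H](CCNS(C)(=O)=O)C[C@H]2c2ccc(F)c(F)c2)oc1Cl`) gives 50 nM, compound 2 (`Cn1ncc(Cl)c1-c1cc(C(=O)N[C@@H]2CN[C@H](CC(O)CO)C[C@H]2c2ccc(F)c(F)c2)oc1Cl`) gives 100 nM and compound 3 (`Cn1ncc(Cl)c1-c1cc(C(=O)N[C@@H]2CN[C@H](CCn3cncn3)C[C@H]2c2ccc(Cl)c(Cl)c2)oc1Cl`) gives 60 nM. All three values lie within the scatter of one another, so compound 3 cannot be separated from either neighbour. Compound 4 (`CN(C)CC[C@@H]1C[C@@H](c2ccc(Cl)c(Cl)c2)[C@H](NC(=O)c2cc(-c3c(Cl)cnn3C)c(Cl)o2)CN1`) keeps compound 3 intact except for one change: dimethylamino in place of 1H-1,2,4-triazol-1-yl on a saturated chain carbon, two bonds along the chain from a saturated ring carbon. Within the data shown here, no measured step involves either group. The closest evidence is a side-chain exchange, a 2.0-fold higher number from compound 1 to compound 2 (0.30 log units; within the scatter), which stays within the scatter. The three side chains so far therefore show no measurable preference, although compound 3 also differs from compound 1 and compound 2 elsewhere on the core. On that thin basis, with compound 3 at 60 nM, no shift beyond the scatter is expected. The expected change is a 1.2-fold lower number from compound 3 to compound 4 (0.08 log units; within the scatter). For compound 4 the estimated value is 50 nM, with an expected range from 15 nM to 170 nM.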

Compound 4, half-maximal inhibitory concentration: 1930 nM
Compound 4: the middle estimate sits 39-fold (1.59 log units) below what was measured; measured number outside the range, above it.
By their numbers in this assay, from the lowest: compounds 1, 3 and 2 (each within the scatter of the next); then compound 4.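

In this assay this position proves sensitive to the group at the end of the chain: dimethylamino in place of 1H-1,2,4-triazol-1-yl gives a 32-fold higher number from compound 3 to compound 4 (1.51 log units; beyond the scatter) and this is the only step shown that lies beyond the scatter. The earlier side-chain exchange stayed within the scatter, so it gave no sign that a single change on this chain could have so large an effect. Nothing available here accounts for the size of this step.

From the compounds shown here alone, it remains open whether a pyrrolidine, a morpholine or an imidazole at the end of the same chain would stay with compound 3 or fall with compound 4. Going by these compounds, it is also open whether the same exchange on the core of compound 1 would give a step of similar size.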